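Swapping the Aryl Group on the Amide Nitrogen

The source may hold more compounds than are shown below. What is called first, only, known or untested is meant among the compounds shown, and "the series" means these compounds.

compound 1 `CCOC(=O)C1=Cc2ccccc2OC1(OCc1cn(CC(=O)Nc2ccc(OC)cc2)nn1)C(F)(F)F`: 32700 nM
compound 2 `O=C(O)C1=Cc2ccccc2OC1(OCc1cc(-c2ccc(F)cc2F)no1)C(F)(F)F`: > 150000 nM

For the measured compounds named here, in a functional assay on DU-145 cells (Homo sapiens) for inhibition, read by MTT assay, with a stated time of 24 h (a lower number here means a stronger inhibitor, a higher number a weaker inhibitor), compound 1 gives 32700 nM, the only proper number among the two measured compounds. Compound 2 reaches only a limit of this assay, > 150000 nM, and no number is known for it; this is the limit of > 150000 nM in this assay, at which 1 of the 2 values shown sits. Going by the values given here, compound 1 and compound 2 differ in several places at once, so no single step between them can be drawn.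

Compound 3 `CCOC(=O)C1=Cc2ccccc2OC1(OCc1cn(CC(=O)Nc2cccc(F)c2)nn1)C(F)(F)F` is not yet measured. It differs from compound 1 in one place: 3-fluorophenyl in place of 4-methoxyphenyl on an amide-type nitrogen. Nothing measured here shows how such a swap moves the read-out, so no shift beyond the usual scatter in this assay is expected in either direction. Compound 3 is therefore estimated at 40000 nM, within a range from 12000 nM to 150000 nM, which means an expected step of a 1.2-fold higher number from compound 1 to compound 3 (0.09 log units; within the scatter).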

Compound 3, half-maximal inhibitory concentration: > 150000 nM
Compound 3: no number, only a limit (the forecaster's own chance of this, stated with the estimate: 20%); middle value at least 3.7-fold (0.57 log units) away from the limit.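

On the amide-type nitrogen, 3-fluorophenyl in place of 4-methoxyphenyl gives an at least 4.5-fold higher number from compound 1 to compound 3 (0.66 log units; beyond the scatter), which shows that the aryl group at this position is not interchangeable in this assay. Compound 3 gives > 150000 nM, a limit and not a number, so the step sets only a lower bound on the size of the change. Compound 3 thus joins compound 2 at the same limit, and only compound 1 has a proper number: the limit of > 150000 nM in this assay, at which 2 of the 3 values shown sit.

The swap removes the methoxy group and adds a fluorine in one step, so the compounds shown cannot tell which of the two matters. A plain phenyl group on the same nitrogen would help to separate them, while a benzyl group would test whether the aryl ring can sit one carbon further out.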